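The compounds below may be only part of what the source reports. "The series", "measured", "known", "first", "only" and "open" are said of these compounds alone.

In a functional assay on HeLa cells (Homo sapiens) for antiproliferative activity, read by MTT assay, with a stated time of 48 h (on this read-out higher numbers stand for weaker inhibition and lower numbers for stronger inhibition), compound 1 (`Cc1ccc2nc(NC(c3cn(-c4ccccc4)nc3-c3cccc(Cl)c3)c3c(O)ccc4ccccc34)sc2c1`) gives 9430 nM and compound 2 (`Cc1cccc(-c2nn(-c3ccccc3)cc2C(Nc2nc3ccccc3s2)c2c(O)ccc3ccccc23)c1`) gives 7020 nM as measured values. Compound 3 (`COc1ccc2nc(NC(c3cn(-c4ccccc4)nc3-c3ccc(F)cc3)c3c(O)ccc4ccccc34)sc2c1`) gives 4630 nM in this assay and thus sits within the scatter of compound 2 and lower than compound 1 beyond the scatter. Compound 4 (`COc1cccc(-c2nn(-c3ccccc3)cc2C(Nc2nc3ccc(OC)cc3s2)c2c(O)ccc3ccccc23)c1`) differs from compound 3 by having 3-methoxyphenyl in place of 4-fluorophenyl on an aromatic carbon of the five-membered aromatic ring with 2 nitrogen. Among the measured compounds shown here, no measured pair differs in one place alone, and the only guide is the narrow spread from compound 3 at 4630 nM to compound 1 at 9430 nM across the series. A step of a 1.3-fold higher number from compound 3 to compound 4 (0.11 log units; within the scatter) is therefore expected in this assay with nothing beyond the scatter in either direction. Compound 4 is estimated at 6000 nM with an expected range from 2500 nM to 13000 nM in repeated measurements.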

Compound 4, half-maximal inhibitory concentration: 10500 nM
Beside the measured number, compound 4's estimate is 1.8-fold (0.24 log units) below it; measured number inside the range.
By their numbers in this assay, from the lowest: compounds 3, 2, 1 and 4 (each within the scatter of the next, the first and the last beyond it).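

Among the compounds shown here, this is the first single-place comparison: in this assay, replacing 4-fluorophenyl with 3-methoxyphenyl on this aromatic carbon gives a 2.3-fold higher number from compound 3 to compound 4 (0.36 log units; beyond the scatter), a modest weakening of inhibition. For the compounds shown here, the aryl group at this carbon therefore affects the antiproliferative read-out, which the earlier compounds could not show. No measurement given here accounts for the step.

The change alters both the substituent and its place on the phenyl ring, so 4-methoxyphenyl would be needed to separate the two. From the compounds shown here alone, whether an aminophenyl or carboxyphenyl group here would strengthen inhibition remains open.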